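Swapping chloro for fluoro in a THP-1 toxicity series

This account rests on a few compounds, and the source may have more. Where it says the series, first, only, none or still open, it means among the compounds named here.

Compound 1 `Cn1c(-c2ccccc2F)cnc1NC(=O)c1ccc(F)cc1`: > 100000 nM
Compound 2 `Cn1c(-c2ccc(Cl)cc2)cnc1NC(=O)c1ccc(F)cc1`: 37000 nM
Compound 3 `Cn1c(-c2ccc(F)cc2)cnc1NC(=O)c1ccc(F)cc1`: not yet measured

Within the data shown here, in a toxicity assay on THP-1 cells (Homo sapiens) for inhibition (a higher number here means that more compound is tolerated, a lower number that less compound is tolerated), compound 2 gives 37000 nM, the only true number so far. Compound 1 gives > 100000 nM, which is a limit of the assay and not a number.

The structural change from compound 2 to compound 3 is fluoro in place of chloro on an aromatic carbon. In words, fluoro takes the place of chloro on an aromatic carbon, para to a large group.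

Among the measured compounds shown here, only one measured step bears on this: an at least 2.7-fold lower number from compound 1 to compound 2 (0.43 log units; beyond the scatter). It lies beyond the usual scatter, but the halogen and its place changed together, so it cannot separate the two. Compound 3 keeps the place found in compound 2 and the halogen found in compound 1, so only part of that step might be reversed. A small move towards a higher number is therefore expected, possibly within the scatter.

The expected change is a 1.5-fold higher number from compound 2 to compound 3 (0.17 log units; within the scatter). For compound 3 the estimated value is 55000 nM, with an expected range from 26000 nM to 100000 nM.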

Compound 3, half-maximal cytotoxic concentration: > 100000 nM
Compound 3: only a limit was reported; the forecaster's own chance of this, stated with the estimate: 30%; middle value at least 1.8-fold (0.25 log units) from the limit.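

With the place on the ring held fixed, the halogen can now be read on its own: in this assay, fluoro in place of chloro on an aromatic carbon, para to a large group, gives an at least 2.7-fold higher number from compound 2 to compound 3 (0.43 log units; beyond the scatter). The earlier step from the 2-fluorophenyl group to the 4-chlorophenyl group changed the halogen and its place together, whereas this step shows that the halogen alone is enough to move the number beyond the scatter, with the place unchanged. Only compound 2, the chloro compound, has a true number, and the full size of the new step stays hidden: the limit of > 100000 nM in this assay, at which 2 of the 3 values shown sit.

The step from compound 1 to compound 3 cannot be read, as both of its values are limits, so the compounds shown do not tell whether moving the fluoro to this place changes the number at all, or how far compound 3 lies from the limit. From the compounds shown here alone, it also remains open whether a larger halogen such as bromo, or a non-halogen group such as methyl or an amine, at this same place would give a number nearer to that of compound 2 or to that of compound 3.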